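Two Inactive Styryl Heteroaryls and a Benzyl Amine Variant

The compounds below may be only part of what the source reports. "The series", "measured", "known", "first", "only" and "open" are said of these compounds alone.

Measured so far:
Compound 1, `CCCc1nn(C)c2c(NCc3ccc(F)cc3)nc(/C=C/c3nc(C)c(C)nc3C)nc12`: > 1000000 nM
Compound 2, `CC(C)Nc1nc(/C=C/c2ccccc2)nc2ccsc12`: > 1000000 nM

Compound 1, `CCCc1nn(C)c2c(NCc3ccc(F)cc3)nc(/C=C/c3nc(C)c(C)nc3C)nc12`, was tested in a functional assay on L02 cells (Homo sapiens) for inhibition, read by Griess assay, with stated times of 1 h and 24 h (a higher number here means a weaker inhibitor, a lower number a stronger inhibitor), and gave only a limit, > 1000000 nM. Compound 2, `CC(C)Nc1nc(/C=C/c2ccccc2)nc2ccsc12`, was tested in the same way, and in this assay compound 2 also gave a limit rather than a number, > 1000000 nM. Where compound 2 stands is therefore set by the limit of > 1000000 nM in this assay, at which 2 of the 2 values shown sit, and nothing finer can be said of it. Going by the values given here, no pair of measured compounds differs in a single place, so no measured step exists from which to read the size of any change.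

The compound not yet measured is compound 3, `Clc1ccccc1CNc1nc(/C=C/c2ccccc2)nc2ccsc12`. It differs from compound 2 by 2-chlorobenzyl in place of isopropyl on a nitrogen on an aromatic ring. Among the compounds with values here, with both known values sitting at a limit, there is no step to lean on, and the expectation for compound 3 is that it too stays at the limit, with no change beyond the scatter. The step expected here is a number no higher from compound 2 to compound 3 (the limit leaves the size open). Compound 3 is thus estimated at 1000000 nM, within 100000 nM to 5000000 nM.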

Compound 3, half-maximal inhibitory concentration: > 1000000 nM
Compound 3 was reported as a limit; the forecaster's own chance of this, stated with the estimate: 75%; the middle value lies on the limit itself.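

Compound 2 and compound 3 both gave only a limit in this assay, so the step between them, 2-chlorobenzyl in place of isopropyl, cannot be read. The compounds shown share one reading: the limit of > 1000000 nM in this assay, at which 3 of the 3 values shown sit. They leave open how strongly any of them inhibits in this assay, and what change, if any, would give a number rather than a limit.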